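Removing the Methyl from the Pyrazole Nitrogen

This account rests on a few compounds, and the source may have more. Where it says the series, first, only, none or still open, it means among the compounds named here.

Compound 2 `Cn1ccc(-c2ccc(Cn3cc(C(=O)N[C@H]4CCOC[C@@H]4O)c4ncccc43)cc2)n1` gives 31.5 10^-6 cm/s in an ADME assay on MDCKII-LE cells (Canis lupus familiaris) for permeability (a lower number here means that the compound crosses the layer more slowly, a higher number that the compound crosses the layer faster), and its nearest neighbour, compound 1 `O=C(N[C@H]1CCOC[C@@H]1O)c1cn(Cc2ccc(-n3cccn3)cc2)c2cccnc12`, gives 21.7 10^-6 cm/s in this assay; the two numbers lie within the scatter of each other. For the measured compounds named here, the only measured step, a 1.5-fold higher number from compound 1 to compound 2 (0.16 log units; within the scatter), concerns a different part of the molecule and so does not speak directly to the change at hand. Compound 3 `O=C(N[C@H]1CCOC[C@@H]1O)c1cn(Cc2ccc(-c3cc[nH]n3)cc2)c2cccnc12` differs from compound 2 in this way: hydrogen in place of methyl on an aromatic nitrogen. Going by the values given here, no measured step covers this change, so the expectation rests on the structural change alone. For compound 3 a moderately lower number is expected in this assay, a step of a 2.3-fold lower number from compound 2 to compound 3 (0.35 log units; beyond the scatter). Compound 3 is estimated at 14 10^-6 cm/s, within a range of 7 10^-6 cm/s to 28 10^-6 cm/s.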

Compound 3, apparent permeability: 14 10^-6 cm/s
For compound 3 middle estimate and measured number coincide at the digits printed; the measured number falls inside the stated range.
By their numbers in this assay, from the lowest: compounds 3, 1 and 2 (each within the scatter of the next, the first and the last beyond it).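

Hydrogen in place of methyl on an aromatic nitrogen, with a 2.3-fold lower number from compound 2 to compound 3 (0.35 log units; beyond the scatter), is the first step in this assay to lie beyond the scatter. Among these three compounds, the methyl on this nitrogen therefore matters more than the way the ring is attached: 1H-pyrazol-3-yl in place of 1H-pyrazol-1-yl, with a 1.6-fold lower number from compound 1 to compound 3 (0.19 log units; within the scatter), stays within it. As far as these compounds go, whether an ethyl group, or a longer chain ending in an amine, on that nitrogen would fall nearer compound 2 or compound 3 stays open. Nothing measured here explains the step.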